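Acetylation of the side-chain hydroxy in two halogenated cores

The compounds below may be only part of what the source reports. "The series", "measured", "known", "first", "only" and "open" are said of these compounds alone.

Compound 2 `CCC[C@@H](O)C1=C(Br)C(=C(Br)Br)OC1=O` and compound 1 `CCC[C@@H](OC(C)=O)C1=C(Br)C(=C(Br)Br)OC1=O` share one core; compound 1 carries the change (acetyl in place of hydrogen on an oxygen on a saturated carbon). In a functional assay on KB cells (Homo sapiens) for cytotoxicity (on this read-out lower numbers stand for an effect already at smaller amounts and higher numbers for an effect only at larger amounts of compound), compound 2 gives 9.5 ug/mL, and compound 1 gives 3.5 ug/mL, which is the step of a 2.7-fold lower number from compound 2 to compound 1 (0.43 log units; beyond the scatter). Compound 3 `CCC[C@@H](O)C1=C(Br)/C(=C/I)OC1=O` rests on a second core; the difference between the two cores is not broken down here. In this assay compound 3 gives 0.3 ug/mL, the lowest of the three numbers. Compound 4 `CCC[C@@H](OC(C)=O)C1=C(Br)/C(=C/I)OC1=O` differs from compound 3 by acetyl in place of hydrogen on an oxygen on a saturated carbon, the same change as between compound 2 and compound 1, at the same place. The expected step in this assay is a 2.5-fold lower number from compound 3 to compound 4 (0.40 log units; beyond the scatter), resting on the measured step of a 2.7-fold lower number from compound 2 to compound 1 (0.43 log units; beyond the scatter). Compound 4 is therefore estimated at 0.12 ug/mL, with a range of 0.04 ug/mL to 0.4 ug/mL.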

Compound 4, concentration for half-maximal effect: 0.2 ug/mL
Compound 4: the middle estimate sits 1.7-fold (0.22 log units) below what was measured; the measured number falls inside the stated range.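

On the second core, acetyl in place of hydrogen on the side-chain oxygen gives a 1.5-fold lower number from compound 3 to compound 4 (0.18 log units; within the scatter) in this assay. Set beside the step on the other core, the two cannot be told apart: the same change on two cores in this assay, a 2.7-fold lower number (0.43 log units; beyond the scatter) from compound 2 to compound 1 and a 1.5-fold lower number (0.18 log units; within the scatter) from compound 3 to compound 4, 1.8-fold (0.26 log units) apart, within the scatter of two such steps. The change therefore carries across these two cores without a detectable difference in size, but this rests on one pair per core, and the second step alone does not establish an effect of acetylation on that core.

Going by these compounds, whether the hydroxy to acetoxy change behaves alike on any further core remains open. Also open, on these data alone, is how a longer acyl chain, a benzoyl ester or an amine at this carbon would compare with the hydroxy and acetoxy forms.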